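This account rests on a few compounds, and the source may have more. Where it says the series, first, only, none or still open, it means among the compounds named here.

Lipophilicity describes how strongly a compound favours a fatty environment over water. In a physicochemical assay for lipophilicity, read by HPLC, at pH 7.5 (on this read-out higher numbers stand for higher lipophilicity and lower numbers for lower lipophilicity), compound 1 (`CCOc1ccccc1-c1ccc(-c2nc3cnccc3c(N)c2C#N)cc1`) gives 3. Compound 2 (`CC(C)(CC(N)=O)c1c(C#N)c(-c2ccc(Br)cc2)nc2cnccc12`) gives 2.1, which leaves compound 1 with the higher of the two numbers, and the gap between them lies beyond the usual scatter.

Compound 3 (`CCOc1ccccc1-c1ccc(-c2nc3cnccc3c(NC(C(N)=O)C3CC3)c2C#N)cc1`) keeps the core of compound 1 and changes one place, on a nitrogen on an aromatic ring: a group of 7 heavy atoms (5 carbon, 1 nitrogen, 1 oxygen; one three-membered non-aromatic ring of carbon only) in place of a hydrogen atom, on a nitrogen on an aromatic ring. A hydrogen atom leaves, and the group that enters holds one three-membered non-aromatic ring of carbon only.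

The two measured compounds differ in more than one place, so neither shows the size of such a change directly, and the expectation remains uncertain. In this assay, the expected change, a number 0.10 log units lower from compound 1 to compound 3 (within the scatter), is small and stays within the usual scatter. For compound 3 the estimated value is 2.9, with an expected range from 2.3 to 3.5.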

Compound 3, distribution coefficient: 3
The estimate for compound 3 lay 0.10 log units below the measured number; measured number inside the range.
By their numbers in this assay, from the lowest: compound 2; then compounds 1 and 3 (each within the scatter of the next).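

At this nitrogen on an aromatic ring, a group of 7 heavy atoms, one three-membered non-aromatic ring of carbon only among them, can replace a hydrogen atom, and this assay records this step as follows: no change at the digits printed from compound 1 to compound 3 (within the scatter). Going by these compounds alone, this is the first direct reading of a change at this position, since compound 2 differs from compound 1 in more than one place. No measurement shown explains the result, and this single pair speaks only for this one group.

From the compounds shown here alone, it remains open whether a simple methyl on this nitrogen, or a chain ending in an amine or a carboxylic acid, would give a similar reading. The compounds shown also cannot separate the effect of the three-membered ring from that of the rest of the group.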